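Trimming the Amine Chain: Ethyl to Methyl

The source may report more compounds than this note shows. Statements on the series, on what has been measured and on what is new or still open speak of the compounds shown alone.

Compound 1, `CCCCCCNc1nc(-c2ccccc2)nc2c1nnn2Cc1ccccc1`, gives 13200000 nM in an assay on isolated protein for binding affinity to adenosine receptor A1 (Bos taurus); a lower number here means a stronger inhibitor, a higher number a weaker inhibitor.
Compound 2, `CNc1nc(-c2ccccc2)nc2c1nnn2Cc1ccccc1F`, gives 25000000 nM in this assay.
Compound 3, `CCNc1nc(-c2ccccc2)nc2c1nnn2Cc1ccccc1`, gives 91000000 nM in this assay.

All three compounds share the same core and differ only in the chain on the amine nitrogen or in the ring attached through the single carbon. Among them, compound 3 stands at the highest number, that is, it is the weakest binder of the three in this assay; compound 2 is nearest to it and compound 1 furthest, and both gaps lie beyond the scatter of repeated measurements.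

Compound 4, `CNc1nc(-c2ccccc2)nc2c1nnn2Cc1ccccc1`, is reached from compound 3 by a single change: hydrogen in place of methyl on a saturated chain carbon bound to a nitrogen on an aromatic ring. For the measured compounds named here, one measured step bears on this change, namely a 6.9-fold higher number from compound 1 to compound 3 (0.84 log units; beyond the scatter), where shortening the same chain raised the number. Going by the values given here, compound 2 carries the methylamino group of compound 4 but also a fluorine on its other ring, and its value is lower than that of compound 3; no step between compound 2 and compound 4 is available, so it only hints that a methylamino chain need not weaken binding further. Taken together, a small shift is expected, its direction uncertain, and the step from compound 3 to compound 4 is estimated at a 1.8-fold lower number from compound 3 to compound 4 (0.26 log units; within the scatter). Compound 4 is therefore expected to give about 50000000 nM in this assay, within a range from 15000000 nM to 200000000 nM.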

Compound 4, inhibition constant: 353000000 nM
Compound 4: middle estimate off by 7.1-fold (0.85 log units), on the low side, outside the stated range (above it).
By their numbers in this assay, from the lowest: compounds 1 and 2 (each within the scatter of the next); then compound 3; then compound 4.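

In this assay, going from ethylamino to methylamino gives a 3.9-fold higher number from compound 3 to compound 4 (0.59 log units; beyond the scatter), so trimming the chain on the amine nitrogen by this last carbon raises the number in the same direction as the earlier step, a 6.9-fold higher number from compound 1 to compound 3 (0.84 log units; beyond the scatter). Across compound 1, compound 3 and compound 4, the number rises each time the chain gets shorter, none of these three goes against that order, and the whole span amounts to a 27-fold higher number from compound 1 to compound 4 (1.43 log units; beyond the scatter). The methylamino chain is also now seen without the fluoro group: with that chain held fixed, removing the fluoro gives a 14-fold higher number from compound 2 to compound 4 (1.15 log units; beyond the scatter), so the low number of compound 2 goes with its fluoro group and does not show that a methylamino chain is tolerated.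

No measurement shown explains why these numbers move as they do. The compounds shown leave open whether a plain amino group with no chain on the nitrogen would continue this rise, whether a chain longer than that of compound 1 would lower the number further, and whether a fluoro group would bring a similar step when paired with the ethylamino chain.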